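A few compounds are considered here, and "the series" means these few. Any claim that something is new, unique, unknown or untested is made for them only; others in the source may bear on it.

Working notes on the series.

The series shares the core of compound 1 `CC1=CC[C@@H]([C@@](C)(O)CCCC(C)(C)NC=S)CC1`, which in a functional assay on OVCAR-3 cells (Homo sapiens) for cytotoxicity, read by sulforhodamine B assay (a higher number here means a weaker inhibitor of growth, a lower number a stronger inhibitor of growth), gives 93700 nM. Compound 2 `CC1=CC[C@@H]([C@@](C)(O)CCCC(C)(C)NC(=S)N/N=C\c2ccc(C)cc2)CC1` gives 11800 nM in this assay, and compound 3 `CC1=CC[C@@H]([C@@](C)(O)CCCC(C)(C)NC(=S)N/N=C\c2ccc(O)cc2)CC1` gives 17400 nM. Compound 2 thus has the lowest number of the three shown; compound 3 sits within the scatter of it, while compound 1 lies well beyond it.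

Compound 4 `CC1=CC[C@@H]([C@@](C)(O)CCCC(C)(C)NC(=S)N/N=C\c2ccc(N(C)C)cc2)CC1` is not yet measured. Relative to compound 2 the change is dimethylamino in place of methyl on an aromatic carbon. For the measured compounds named here, the only measured step that bears on a swap of the group on that aromatic carbon is the one from compound 2 to compound 3, which read a 1.5-fold higher number from compound 2 to compound 3 (0.17 log units; within the scatter). Going by the values given here, no step with dimethylamino on an aromatic carbon has been measured, so the expectation rests on that single step alone.

On this basis no step beyond the scatter is expected for compound 4 in this assay, giving a 1.1-fold lower number from compound 2 to compound 4 (0.03 log units; within the scatter) as the estimated change. Compound 4 is therefore estimated at 11000 nM, with a range of 4000 nM to 30000 nM.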

Compound 4, concentration for total growth inhibition: > 100000 nM
Compound 4 was reported as a limit (the forecaster's own chance of this, stated with the estimate: 5%); at least 9.0-fold (0.95 log units) between middle value and limit.
By their numbers in this assay, from the lowest: compounds 2 and 3 (each within the scatter of the next); then compound 1. At a limit, above all of these: compound 4.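

The group on this aromatic carbon, para to a large group, is not indifferent in this assay: hydroxy in place of methyl gave a 1.5-fold higher number from compound 2 to compound 3 (0.17 log units; within the scatter), whereas dimethylamino gives an at least 8.4-fold higher number from compound 2 to compound 4 (0.92 log units; beyond the scatter). Measured from hydroxy, dimethylamino gives an at least 5.7-fold higher number from compound 3 to compound 4 (0.75 log units; beyond the scatter), so the closeness of the methyl and hydroxy compounds does not extend to dimethylamino. The value of compound 4 is a limit of the assay and not a number: the limit of > 100000 nM in this assay, at which 1 of the 4 values shown sits.

The compounds shown do not tell what separates dimethylamino from methyl and hydroxy, and no property of these groups is measured here. As far as these compounds go, it stays open whether a primary amine, a methoxy group or a chlorine on the same aromatic carbon would stay with methyl and hydroxy or go with dimethylamino.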